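Moving fluorine from 2-fluorophenyl to 4-fluorophenyl on compound 3

A few compounds are considered here, and "the series" means these few. Any claim that something is new, unique, unknown or untested is made for them only; others in the source may bear on it.

In a functional assay on MCF7 cells (Homo sapiens) for antiproliferative activity, read by MTT assay (on this read-out lower numbers stand for stronger inhibition and higher numbers for weaker inhibition), compound 1 `COc1cc2c(Oc3ccc(NC(=O)Nc4ccccc4C(F)(F)F)cc3)ccnc2cc1OCCCCCCC(=O)NO` gives 1080 nM and compound 2 `COc1ccccc1NC(=O)Nc1ccc(Oc2ccnc3cc(OCCCCCCC(=O)NO)c(OC)cc23)cc1` gives 6280 nM. Compound 3 `COc1cc2c(Oc3ccc(NC(=O)N/N=C/c4ccccc4F)cc3)ccnc2cc1OCCCCCCC(=O)NO`, at 1610 nM, stands within the scatter of its closest neighbour, as a 1.5-fold higher number from compound 1 to compound 3 (0.17 log units; within the scatter) shows, and well clear of the other, as a 3.9-fold lower number from compound 2 to compound 3 (0.59 log units; beyond the scatter) shows. Compound 4 `COc1cc2c(Oc3ccc(NC(=O)N/N=C/c4ccc(F)cc4)cc3)ccnc2cc1OCCCCCCC(=O)NO` differs from compound 3 by 4-fluorophenyl in place of 2-fluorophenyl on a carbon with a double bond to nitrogen, and the two have the same atoms, joined differently. Going by the values given here, no measured step is of this kind. The nearest guide, a 5.8-fold higher number from compound 1 to compound 2 (0.76 log units; beyond the scatter), exchanged one group for a different one and stayed modest, so a shift of fluorine alone is expected to stay within the scatter. The expected step is a 1.1-fold higher number from compound 3 to compound 4 (0.05 log units; within the scatter). The estimated value for compound 4 is 1800 nM, with an expected range of 700 nM to 4500 nM.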

Compound 4, half-maximal inhibitory concentration: 1360 nM
Compound 4: the middle estimate sits 1.3-fold (0.12 log units) above what was measured; measured number inside the range.
By their numbers in this assay, from the lowest: compounds 1, 4 and 3 (each within the scatter of the next); then compound 2.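

In this assay, the 2-fluorophenyl and 4-fluorophenyl groups on the carbon with a double bond to nitrogen cannot be told apart, with a 1.2-fold lower number from compound 3 to compound 4 (0.07 log units; within the scatter). Compound 4 also keeps the standing of compound 3 against the other two: a 1.3-fold higher number from compound 1 to compound 4 (0.10 log units; within the scatter), while a 4.6-fold lower number from compound 2 to compound 4 (0.66 log units; beyond the scatter). No measurement here offers a reason for this tolerance. Still open, from the compounds shown here alone, is whether the ring tolerates anything other than fluorine, such as a nitrile or an amine, and whether it needs a substituent at all.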